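A few compounds are considered here, and "the series" means these few. Any claim that something is new, unique, unknown or untested is made for them only; others in the source may bear on it.

Working notes on the dione series in a functional assay on CCRF-CEM cells (Homo sapiens) for inhibition, read by MTT assay, with a stated time of 72 h; a lower number here means a stronger inhibitor, a higher number a weaker inhibitor. Compound 2 `COc1ccc(-c2c(-c3cc(OC)c(OC)c(OC)c3)c(=O)c2=O)cc1N` gives 1.4 nM, the lowest of the three numbers recorded. Compound 3 `COc1ccc(-c2c(-c3cc(OC)c(OC)c(OC)c3)c(=O)c2=O)c(OC)c1` gives 1770 nM, and compound 1 `COc1ccc(-c2c(-c3cc(OC)c(OC)c(OC)c3)c(=O)c2=O)cc1[N+](=O)[O-]` gives 12200 nM. Going by the values given here, the one single-site step measured, an 8700-fold lower number from compound 1 to compound 2 (3.94 log units; beyond the scatter), is the amino in place of nitro on an aromatic carbon. It bears directly on compound 4 `COc1cc(-c2c(-c3ccc4[nH]ccc4c3)c(=O)c2=O)cc(OC)c1OC`: the amino that it introduced is part of what leaves there: 1H-indol-5-yl in place of 3-amino-4-methoxyphenyl on an aromatic carbon. With the amino gone and only the indole hydrogen-bond donor entering, a large step toward a higher number is expected, in the region where compound 3 stands. Compound 4 is estimated at 1000 nM (range 80 nM to 12000 nM), an expected step of a 710-fold higher number from compound 2 to compound 4 (2.85 log units; beyond the scatter).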

Compound 4, half-maximal inhibitory concentration: 15.4 nM
The estimate for compound 4 lay 65-fold (1.81 log units) above the measured number; the whole stated range lies above it.
By their numbers in this assay, from the lowest: compound 2; then compound 4; then compound 3; then compound 1.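

The step of an 11-fold higher number from compound 2 to compound 4 (1.04 log units; beyond the scatter) is large, yet it shows that a low number at this position does not depend on the 3-amino-4-methoxyphenyl group: a fused 1H-indol-5-yl, with no amino group on a phenyl ring, still gives a nanomolar inhibitor. Going by these compounds alone, the earlier step changed only one group on the phenyl ring, whereas this one replaces the whole aryl group. Nothing measured here accounts for the size of the step.

The compounds shown leave open whether the indole hydrogen helps to hold the number low. An indole with a methyl group on its nitrogen would bear on that.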